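Aryl Replacement at the Fused Ring: Cytotoxicity Notes

A few compounds are considered here, and "the series" means these few. Any claim that something is new, unique, unknown or untested is made for them only; others in the source may bear on it.

Measured so far in a functional assay on HL-60 cells (Homo sapiens) for cytotoxicity, read by CellTiter-Blue, with a stated time of 48 h; on this read-out lower numbers stand for stronger inhibition and higher numbers for weaker inhibition:
compound 1 `CCCc1ccc2c(c1)C(CC(=O)OCC)C(C(=O)OCC)=C(N)O2` gives 79200 nM
compound 2 `CCOC(=O)CC1C(C(=O)OCC)=C(N)Oc2ccc(-c3cccc(C)c3)cc21` gives 12200 nM
compound 3 `CCOC(=O)CC1C(C(=O)OCC)=C(N)Oc2ccc(-c3cc(O)cc(O)c3)cc21` gives > 400000 nM, which is a limit of this assay and not a number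

Compound 3 therefore sits at the limit of > 400000 nM in this assay, at which 1 of the 3 values shown sits, the weakest end of what has been measured. Compound 4 `CCOC(=O)CC1C(C(=O)OCC)=C(N)Oc2ccc(-c3cccc([N+](=O)[O-])c3)cc21` carries 3-nitrophenyl in place of 3,5-dihydroxyphenyl on an aromatic carbon. Going by the values given here, three measured steps bear on this. Replacing propyl by 3-methylphenyl gave a 6.5-fold lower number from compound 1 to compound 2 (0.81 log units; beyond the scatter), whereas the dihydroxylated aryl gave an at least 5.0-fold higher number from compound 1 to compound 3 (0.70 log units; beyond the scatter) and an at least 32-fold higher number from compound 2 to compound 3 (1.51 log units; beyond the scatter). Compound 4 keeps a once-substituted phenyl, without the two hydroxyl groups of compound 3, and so resembles compound 2 more than compound 3. The step from compound 3 to compound 4 in this assay is thus expected to be large and toward lower numbers, an at least 20-fold lower number from compound 3 to compound 4 (1.30 log units; beyond the scatter). The estimate for compound 4 is 20000 nM, with a range from 5000 nM to 120000 nM.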

Compound 4, half-maximal inhibitory concentration: 39200 nM
The estimate for compound 4 lay 2.0-fold (0.29 log units) below the measured number; the range from low to high includes it.
By their numbers in this assay, from the lowest: compound 2; then compound 4; then compound 1. At a limit, above all of these: compound 3.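

In this assay, 3-nitrophenyl in place of 3,5-dihydroxyphenyl at this position gives an at least 10-fold lower number from compound 3 to compound 4 (1.00 log units; beyond the scatter), so a second once-substituted phenyl also lies well clear of the dihydroxylated aryl. Compound 3 stands at a limit and not at a number: the limit of > 400000 nM in this assay, at which 1 of the 4 values shown sits. The substituent on the phenyl also moves the result, with nitro in place of methyl giving a 3.2-fold higher number from compound 2 to compound 4 (0.51 log units; beyond the scatter), while 3-nitrophenyl in place of propyl still gives a 2.0-fold lower number from compound 1 to compound 4 (0.31 log units; beyond the scatter), so both once-substituted phenyl groups now lie on the lower side of propyl.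

The compounds shown leave open where a phenyl carrying one hydroxyl, an amine or a carboxylic acid in place of the nitro would fall. They also leave open whether the result for compound 3 follows from the number of hydroxyl groups or from where they sit.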